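The source may report more compounds than this note shows. Statements on the series, on what has been measured and on what is new or still open speak of the compounds shown alone.

In a functional assay on PANC-1 cells (Homo sapiens) for antiproliferative activity, read by fluorescence and resazurin assay, with a stated time of 48 h (on this read-out higher numbers stand for weaker inhibition and lower numbers for stronger inhibition), compound 3 `O=C(N/N=C/c1ccncc1)c1cc2cc([N+](=O)[O-])ccc2oc1=O` gives 26100 nM, which lies within the scatter of compound 2 `O=C(N/N=C/c1ccncc1)c1cc2cc(Br)ccc2oc1=O` at 25700 nM and of compound 1 `O=C(N/N=C/c1cccnc1)c1cc2ccccc2oc1=O` at 15300 nM. Compound 4 `O=C(N/N=C/c1cccnc1)c1cc2cc([N+](=O)[O-])ccc2oc1=O` differs from compound 3 as follows: pyridin-3-yl in place of pyridin-4-yl on a carbon with a double bond to nitrogen. This places pyridin-3-yl in place of pyridin-4-yl on a carbon with a double bond to nitrogen. Going by the values given here, the only measured step, a 1.0-fold higher number from compound 2 to compound 3 (0.01 log units; within the scatter), concerns another place in the molecule, so it bears on this change only indirectly. Compound 1 already carries pyridin-3-yl, and its 15300 nM shows no separation beyond the scatter. The expected change in this assay is therefore none beyond the scatter, with an estimated 1.2-fold lower number from compound 3 to compound 4 (0.07 log units; within the scatter). Compound 4 is estimated at 22000 nM, with an expected range of 11000 nM to 42000 nM.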

Compound 4, half-maximal inhibitory concentration: 11800 nM
Compound 4: the middle estimate sits 1.9-fold (0.27 log units) above what was measured; the measured number falls inside the stated range.
By their numbers in this assay, from the lowest: compounds 4, 1, 2 and 3 (each within the scatter of the next, the first and the last beyond it).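

In this assay, going by these compounds alone, the move from pyridin-4-yl to pyridin-3-yl on a carbon with a double bond to nitrogen gives a 2.2-fold lower number from compound 3 to compound 4 (0.34 log units; beyond the scatter) and is the first comparison at this position, a modest step beyond the scatter. With pyridin-3-yl kept, a nitro group added to the shared core gives a 1.3-fold lower number from compound 1 to compound 4 (0.11 log units; within the scatter) and stays within the scatter. Nothing available explains the pyridine step.

Going by these compounds, whether the same pyridine change holds with bromo or hydrogen on the shared core remains open. So does the outcome with pyridin-2-yl or phenyl at this position.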